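Nitro position shift across two cores

The compounds below may be only part of what the source reports. "The series", "measured", "known", "first", "only" and "open" are said of these compounds alone.

Compound 1 `Cc1ncc([N+](=O)[O-])n1CC(O)CSC(=S)N1CCN(C(=O)OC(C)(C)C)CC1` and compound 3 `Cc1nc([N+](=O)[O-])cn1CC(O)CSC(=S)N1CCN(C(=O)OC(C)(C)C)CC1` share one core; compound 2 `Cc1ncc([N+](=O)[O-])n1CC(O)CN1CCN(c2cccc(Cl)c2Cl)CC1` carries another, and the difference between the two cores is not broken down here. In a toxicity assay on HeLa cells (Homo sapiens) for cytotoxicity, read by MTT assay, with a stated time of 24 h (on this read-out lower numbers stand for stronger inhibition and higher numbers for weaker inhibition), compound 1 gives 689000 nM. Compound 3 reaches only the limit of > 5000000 nM in this assay. Compound 2 likewise sits at the limit of > 5000000 nM. Among the measured compounds shown here, the single measured step, (2-methyl-4-nitro-1H-imidazol-1-yl in place of 2-methyl-5-nitro-1H-imidazol-1-yl on a saturated chain carbon, two bonds along the chain from an oxygen on a saturated carbon), produces an at least 7.2-fold higher number from compound 1 to compound 3 (0.86 log units; beyond the scatter); its size is bounded because of the limit of > 5000000 nM in this assay, at which 2 of the 3 values shown sit. Compound 4 `Cc1nc([N+](=O)[O-])cn1CC(O)CN1CCN(c2cccc(Cl)c2Cl)CC1` is not yet measured and differs from compound 2 by 2-methyl-4-nitro-1H-imidazol-1-yl in place of 2-methyl-5-nitro-1H-imidazol-1-yl on a saturated chain carbon, two bonds along the chain from an oxygen on a saturated carbon, the same change at the same place. Compound 2 already rests at the limit of > 5000000 nM. Given the measured at least 7.2-fold higher number from compound 1 to compound 3 (0.86 log units; beyond the scatter), which moved the number upward, compound 4 is expected to stay at or beyond that limit in this assay, so a reported number is unlikely. The step is expected to be a step that the limit leaves unreadable from compound 2 to compound 4, resting on the measured at least 7.2-fold higher number from compound 1 to compound 3 (0.86 log units; beyond the scatter). Compound 4 is estimated at 10000000 nM, between 4000000 nM and 40000000 nM.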

Compound 4, half-maximal inhibitory concentration: 3620000 nM
Compound 4: the middle estimate sits 2.8-fold (0.44 log units) above what was measured; the whole stated range lies above it.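

On the core of compound 2, 2-methyl-4-nitro-1H-imidazol-1-yl in place of 2-methyl-5-nitro-1H-imidazol-1-yl gives an at least 1.3-fold lower number from compound 2 to compound 4 (0.14 log units; that floor lies within the scatter) in this assay. The change therefore does not carry over as one fixed shift from one core to the other: the same change on two cores in this assay, an at least 7.2-fold higher number (0.86 log units; beyond the scatter) from compound 1 to compound 3 and an at least 1.3-fold lower number (0.14 log units; that floor lies within the scatter) from compound 2 to compound 4, at least 10-fold (1.00 log units) apart, beyond the scatter of two such steps Neither step has an exact size, so this shows a dependence on the core in two cases only, gives no rule for further cores and leaves the true gap between the steps unknown: the limit of > 5000000 nM in this assay, at which 2 of the 4 values shown sit.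

Left open is how the same change behaves with an amine or a carboxylic acid in place of the hydroxyl on the chain, or with a longer chain carrying the nitroimidazole. Exact numbers for compound 2 and compound 3 also remain open; each is recorded only as a limit.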